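Swapping Bromo for Methyl: What to Expect of Compound 4

This account rests on a few compounds, and the source may have more. Where it says the series, first, only, none or still open, it means among the compounds named here.

Measured so far in an ADME assay on NIH3T3 cells (Mus musculus) for cytotoxicity, read by MTT assay, with a stated time of 24 h; on this read-out higher numbers stand for weaker inhibition and lower numbers for stronger inhibition:
Compound 1 `O=C(CSc1nnnn1-c1ccccc1)N/N=c1/scc(-c2ccc(Br)cc2)n1-c1ccccc1` gives 433 ug/mL.
Compound 2 `Cc1ccc(-c2cs/c(=N/NC(=O)CSc3nnnn3-c3ccccc3)n2-c2ccccc2)cc1` gives only a limit of the assay, > 500 ug/mL.
Compound 3 `Cc1nnc(SCC(=O)N/N=c2/scc(-c3ccc(Br)cc3)n2-c2ccccc2)s1` gives 55 ug/mL.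

Compound 3 and compound 1 share a core but differ at one spot: 5-methyl-1,3,4-thiadiazol-2-yl in place of 1-phenyl-1H-tetrazol-5-yl on a sulfur. That change produced a 7.9-fold lower number from compound 1 to compound 3 (0.90 log units; beyond the scatter) in this assay, leaving compound 3 with the lowest number of the two that are known.

Compound 2 differs from compound 1 by methyl in place of bromo on an aromatic carbon, and that change gave an at least 1.1-fold higher number from compound 1 to compound 2 (0.06 log units; that floor lies within the scatter). Since compound 2 sits at the limit of > 500 ug/mL in this assay, at which 1 of the 3 values shown sits, the true size of that step is not known, only its floor.

Compound 4 `Cc1ccc(-c2cs/c(=N/NC(=O)CSc3nnc(C)s3)n2-c2ccccc2)cc1` has not been measured. It differs from compound 3 by methyl in place of bromo on an aromatic carbon, the same change as from compound 1 to compound 2, at the same kind of place. Starting from compound 3 at 55 ug/mL, a move of roughly a 2.0-fold higher number from compound 3 to compound 4 (0.30 log units; within the scatter) is expected in this assay, resting on the step of an at least 1.1-fold higher number from compound 1 to compound 2 (0.06 log units; that floor lies within the scatter). Compound 4 is therefore estimated at about 110 ug/mL, with a likely range of 50 ug/mL to 300 ug/mL.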

Compound 4, half-maximal inhibitory concentration: 373 ug/mL
The estimate for compound 4 lay 3.4-fold (0.53 log units) below the measured number; measured number above the stated range.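

In this assay, methyl in place of bromo on an aromatic carbon gave a 6.8-fold higher number from compound 3 to compound 4 (0.83 log units; beyond the scatter), while 5-methyl-1,3,4-thiadiazol-2-yl in place of 1-phenyl-1H-tetrazol-5-yl on a sulfur gave an at least 1.3-fold lower number from compound 2 to compound 4 (0.12 log units; that floor lies within the scatter). Compound 2 is known only as a limit of the assay, so the bromo-to-methyl change has a firm size on just one core, which shows that it can be sizeable but not that it carries over unchanged from core to core: the same change on two cores in this assay, an at least 1.1-fold higher number (0.06 log units; that floor lies within the scatter) from compound 1 to compound 2 and a 6.8-fold higher number (0.83 log units; beyond the scatter) from compound 3 to compound 4; the limit leaves it open whether they differ The change on the sulfur has the same gap, with a firm size only between the two bromo compounds: the same change on two cores in this assay, a 7.9-fold lower number (0.90 log units; beyond the scatter) from compound 1 to compound 3 and an at least 1.3-fold lower number (0.12 log units; that floor lies within the scatter) from compound 2 to compound 4; the limit leaves it open whether they differ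

The compounds shown leave open what a chloro, a methoxy or an amine would do in place of the bromo on the aromatic ring. They also leave open how a carboxylic acid or a longer chain would behave on the sulfur side of the shared core.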